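Chloro on the Phenylcarbamoyl Ring: Measured and Expected

This account rests on a few compounds, and the source may have more. Where it says the series, first, only, none or still open, it means among the compounds named here.

Compound 1 `CN(C)CCNc1nc(-c2ccc(NC(=O)Nc3ccccc3)cc2)nc2ccsc12` and compound 2 `CN(C)CCNc1nc(-c2ccc(NC(=O)Nc3ccccc3Cl)cc2)nc2ccsc12` share one core and differ in a single place: chloro in place of hydrogen on an aromatic carbon. In a functional assay on HT-29 cells (Homo sapiens) for cytotoxicity, read by MTT assay, with a stated time of 72 h (a higher number here means a weaker inhibitor, a lower number a stronger inhibitor), compound 1 gives 620 nM, and compound 2 gives 310 nM, so that a 2.0-fold lower number from compound 1 to compound 2 (0.30 log units; within the scatter).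

Compound 3 `CCN(CC)CCNc1nc(-c2ccc(NC(=O)Nc3ccccc3Cl)cc2)nc2c(Cl)c(Cl)sc12` carries a different core; how it differs from compound 1 is not broken down here. In this assay compound 3 gives 550 nM, which sits within the scatter of compound 1 and of compound 2.

Compound 4 `CCN(CC)CCNc1nc(-c2ccc(NC(=O)Nc3ccc(Cl)cc3Cl)cc2)nc2c(Cl)c(Cl)sc12` is made from compound 3 by the same kind of change: chloro in place of hydrogen on an aromatic carbon. The surroundings are not identical, since the new chloro in compound 4 is meta to a chloro group and para to a large group, while in compound 2 it is ortho to a large group.

Because the earlier step of a 2.0-fold lower number from compound 1 to compound 2 (0.30 log units; within the scatter) stayed within the scatter, a similarly modest step is expected, a 1.4-fold lower number from compound 3 to compound 4 (0.14 log units; within the scatter), from compound 3 to compound 4. Compound 4 is therefore estimated at 400 nM, with a likely range from 200 nM to 900 nM.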

Compound 4, half-maximal inhibitory concentration: 1140 nM
The estimate for compound 4 lay 2.9-fold (0.45 log units) below the measured number, outside the stated range (above it).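

Going from the (2-chlorophenyl)carbamoyl group to the (2,4-dichlorophenyl)carbamoyl group brought a 2.1-fold higher number from compound 3 to compound 4 (0.32 log units; beyond the scatter) in this assay, so here the added chloro goes with a weaker inhibitor. Set beside the earlier step, the exchange of hydrogen for chloro did not carry over unchanged from one core to the other: the same change on two cores in this assay, a 2.0-fold lower number (0.30 log units; within the scatter) from compound 1 to compound 2 and a 2.1-fold higher number (0.32 log units; beyond the scatter) from compound 3 to compound 4, 4.1-fold (0.62 log units) apart, beyond the scatter of two such steps. This shows that the result of adding a chloro in one pair cannot simply be transferred to the other, but it does not show which difference between the pairs matters, since they differ in the core, in the amine chain and in where the new chloro sits.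

The compounds shown leave open whether the step from 2-chlorophenyl to 2,4-dichlorophenyl would give a similar result on the core of compound 1. They also leave open whether a fluoro or a methoxy group in the place of the new chloro would follow the same course.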